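The source may report more compounds than this note shows. Statements on the series, on what has been measured and on what is new or still open speak of the compounds shown alone.

Compounds measured in a functional assay on MCF7 cells (Homo sapiens) for cytotoxicity, read by neutral red uptake, with a stated time of 3 days; a higher number here means a weaker inhibitor, a lower number a stronger inhibitor:
Compound 1, `Nc1ccc(-c2cc(=O)c3c(N)c(F)cc(F)c3o2)cc1F`, gives 40 nM.
Compound 2, `CCCCCCc1c(F)c(N)c2c(=O)cc(-c3ccc(N)c(F)c3)oc2c1F`, reaches only the limit of the assay, > 10000 nM.
Compound 3, `Nc1ccc(-c2cc(=O)c3c(N)c(F)c(Cl)c(F)c3o2)cc1F`, gives 210 nM.

Compound 1 holds the lowest of the two numbers; its nearest neighbour is compound 3, with a 5.3-fold higher number from compound 1 to compound 3 (0.72 log units; beyond the scatter). Compound 4, `COCc1c(F)c(N)c2c(=O)cc(-c3ccc(N)c(F)c3)oc2c1F`, differs from compound 1 in one place: methoxymethyl in place of hydrogen on an aromatic carbon. For the measured compounds named here, two measured steps bear on this change, both at the same aromatic carbon: an at least 250-fold higher number from compound 1 to compound 2 (2.39 log units; beyond the scatter) and a 5.3-fold higher number from compound 1 to compound 3 (0.72 log units; beyond the scatter). Each substitution there raised the number, the hexyl by a large step, the chloro by a modest one, so a step upward beyond the scatter is expected for compound 4, a 38-fold higher number from compound 1 to compound 4 (1.57 log units; beyond the scatter). Compound 4 is therefore estimated at 1500 nM, in the range 300 nM to 8000 nM.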

Compound 4, half-maximal inhibitory concentration: 46 nM
Compound 4: the middle estimate sits 33-fold (1.51 log units) above what was measured, outside the stated range (below it).
By their numbers in this assay, from the lowest: compounds 1 and 4 (each within the scatter of the next); then compound 3. At a limit, above all of these: compound 2.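

Methoxymethyl on this aromatic carbon stays within the scatter of hydrogen, with a 1.2-fold higher number from compound 1 to compound 4 (0.06 log units; within the scatter), so a substituent here does not of itself raise the number in this assay. Against the other two groups at this carbon the change does count, with a 4.6-fold lower number from compound 3 to compound 4 (0.66 log units; beyond the scatter) and an at least 210-fold lower number from compound 2 to compound 4 (2.33 log units; beyond the scatter). Compound 2 stands at a limit, not a number: the limit of > 10000 nM in this assay, at which 1 of the 4 values shown sits.

The compounds shown do not separate the oxygen of methoxymethyl from its shorter chain. An ethyl or propyl chain on this carbon, or a hydroxymethyl group, would bear on that.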